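Compound 4: a ring swap on a fluoro compound

The source may report more compounds than this note shows. Statements on the series, on what has been measured and on what is new or still open speak of the compounds shown alone.

Values measured in a functional assay on HeLa cells (Homo sapiens) for cytotoxicity, read by MTT assay, with a stated time of 48 h (a lower number here means a stronger inhibitor, a higher number a weaker inhibitor), follow
- Compound 1 `C=C1OC(=O)C=C1Cc1ccc(NC(=O)/C=C/c2ccccc2)cc1` gives 7340 nM
- Compound 2 `C=C1OC(=O)C=C1Cc1ccc(NC(=O)/C=C/c2ccccc2F)cc1` gives 6930 nM
- Compound 3 `O=C(/C=C/c1ccc(F)cc1)Nc1ccc(CC2=CC(=O)OC2)cc1` gives > 50000 nM

In this assay compound 3 reads > 50000 nM and this is a limit, not a number. Within the data shown here, compound 4 (`C=C1OC(=O)C=C1Cc1ccc(NC(=O)/C=C/c2ccc(F)cc2)cc1`) differs from compound 3 in one group (a group of 7 heavy atoms (5 carbon, 2 oxygen; one five-membered non-aromatic ring with 1 hetero atom) in place of a group of 6 heavy atoms (4 carbon, 2 oxygen; one five-membered non-aromatic ring with 1 hetero atom), on a saturated chain carbon bound to an aromatic carbon) and no measured step covers that change directly. Compounds 1 and 2 carry the entering group, and the fluoro swap between them (a 1.1-fold lower number from compound 1 to compound 2 (0.02 log units; within the scatter)) stays within the scatter. Compound 2 gives 6930 nM with that group, so a clear move toward a lower number is expected in this assay. The expected step is an at least 7.1-fold lower number from compound 3 to compound 4 (0.85 log units; beyond the scatter) and it is only an estimate. The estimate for compound 4 is 7000 nM (expected range 3000 nM to 16000 nM).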

Compound 4, half-maximal inhibitory concentration: 2770 nM
Estimate against measurement, compound 4: 2.5-fold (0.40 log units) above; measured number outside the range, below it.
By their numbers in this assay, from the lowest: compound 4; then compounds 2 and 1 (each within the scatter of the next). At a limit, above all of these: compound 3.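

Where the fluoro sits turns out to matter, which the earlier fluoro swap did not show: 4-fluorophenyl in place of 2-fluorophenyl gives (a 2.5-fold lower number from compound 2 to compound 4 (0.40 log units; beyond the scatter)), and fluoro in place of hydrogen gives (a 2.6-fold lower number from compound 1 to compound 4 (0.42 log units; beyond the scatter)). In this assay, the ring group on the saturated chain carbon also matters, with 3 double bonds outside aromatic rings in place of 2 (an at least 18-fold lower number from compound 3 to compound 4 (1.25 log units; beyond the scatter)). Compound 3 reads as a limit, not a number: the limit of > 50000 nM in this assay, at which 1 of the 4 values shown sits.

Going by these compounds, whether the 4-position prefers fluoro over a chloro or a methoxy group stays open. So does whether a ring group carrying an amine on that chain carbon would hold up in the same test.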